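The source may hold more compounds than are shown below. What is called first, only, known or untested is meant among the compounds shown, and "the series" means these compounds.

Compound 1 `O=c1cc(CNCc2ccccc2)oc2ccc(O)c(O)c12` is the reference point of this small set. In an ADME assay on Huh-7 cells (Homo sapiens) for cytotoxicity (a lower number here means that less compound is tolerated, a higher number that more compound is tolerated), compound 1 gives only a limit of the assay, > 100000 nM. Compound 3 `O=c1cc(CNCc2cccc(O)c2)oc2ccc(O)c(O)c12`, with hydroxy in place of hydrogen on an aromatic carbon, likewise reaches only a limit, > 100000 nM. Compound 2 `O=c1cc(CNCc2ccccc2I)oc2ccc(O)c(O)c12`, with iodo in place of hydrogen on an aromatic carbon, gives 87300 nM in this assay, a change of an at least 1.1-fold lower number from compound 1 to compound 2 (0.05 log units; that floor lies within the scatter). Because the limit of > 100000 nM in this assay, at which 2 of the 3 values shown sit, two of the three values sit at the ceiling, the set leaves little room for a readable shift. Compound 4 `O=c1cc(CNCc2ccc(I)cc2)oc2ccc(O)c(O)c12` differs from compound 1 by iodo in place of hydrogen on an aromatic carbon. For the measured compounds named here, the only step that bears on it, an at least 1.1-fold lower number from compound 1 to compound 2 (0.05 log units; that floor lies within the scatter), lay within the scatter, so no movement beyond the scatter is expected. Compound 4 is therefore estimated at 90000 nM, between 40000 nM and 200000 nM, an expected step of an at least 1.1-fold lower number from compound 1 to compound 4 (0.04 log units; that floor lies within the scatter).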

Compound 4, half-maximal cytotoxic concentration: 41700 nM
Estimate against measurement, compound 4: 2.2-fold (0.33 log units) above; the measured number falls inside the stated range.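

With iodo para to a large group, this assay now shows a shift beyond the scatter: an at least 2.3-fold lower number from compound 1 to compound 4 (0.37 log units; beyond the scatter), and an at least 2.3-fold lower number from compound 3 to compound 4 (0.37 log units; beyond the scatter). The two iodo compounds also separate, with a 2.1-fold lower number from compound 2 to compound 4 (0.32 log units; beyond the scatter), so in this pair the place of the iodo on the ring goes with a change in the number.

As far as these compounds go, the full size of the steps starting from compound 1 and compound 3 stays open because of a single ceiling: the limit of > 100000 nM in this assay, at which 2 of the 4 values shown sit. From the compounds shown here alone, whether chloro or methoxy at the same place would move the number as iodo does also remains open.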